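The source may hold more compounds than are shown below. What is called first, only, known or untested is meant among the compounds shown, and "the series" means these compounds.

Measured in a functional assay on U-937 cells (Homo sapiens) for cytotoxicity, read by MTT assay, with a stated time of 72 h; on this read-out lower numbers stand for stronger inhibition and higher numbers for weaker inhibition:
- compound 1 `Cc1c(C)c2c(c(C)c1OC(=O)CCC(=O)O)CCC(C)(C(=O)NCC1CC(C)(C)N([O])C1(C)C)O2`: 24000 nM
- compound 2 `Cc1c(C)c2c(c(C)c1O)CCC(C)(C(=O)NCC1CC(C)(C)N([O])C1(C)C)O2`: 134000 nM
- compound 3 `Cc1c(C)c2c(c(C)c1OC(=O)CCC(=O)NCC1CC(C)(C)N([O])C1(C)C)CCC(C)(C(=O)NCC1CC(C)(C)N([O])C1(C)C)O2`: 61000 nM

Of these three, compound 1 gives the lowest number, 24000 nM. Compound 4 `Cc1c(C)c2c(c(C)c1OC(=O)CCC(=O)O)CCC(C)(C(=O)NC1CC(C)(C)N([O])C1(C)C)O2` has not yet been measured. It departs from compound 1 on an amide-type nitrogen whose other neighbours are: carbonyl carbon. The difference there is a group of 10 heavy atoms (8 carbon, 1 nitrogen, 1 oxygen; one five-membered non-aromatic ring with 1 hetero atom) in place of a group of 11 heavy atoms (9 carbon, 1 nitrogen, 1 oxygen; one five-membered non-aromatic ring with 1 hetero atom), on an amide-type nitrogen. Both groups hold one five-membered non-aromatic ring with 1 hetero atom.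

Among the measured compounds shown here, no measured step touches this place on its own. The two steps at hand change something else. There is a 5.6-fold higher number from compound 1 to compound 2 (0.75 log units; beyond the scatter) with hydrogen in place of (2-carboxyethyl)carbonyl on an oxygen on an aromatic ring. There is also a 2.5-fold higher number from compound 1 to compound 3 (0.41 log units; beyond the scatter) with a larger group put in place of one oxygen atom, on a carbonyl carbon. Both are modest, and both lead away from the low number of compound 1, so they give only a rough idea of how far this series moves. For the much smaller change in compound 4, no step beyond the scatter is expected in this assay. The expected step is a 1.2-fold higher number from compound 1 to compound 4 (0.07 log units; within the scatter). Compound 4 is estimated at 28000 nM, with an expected range of 12000 nM to 65000 nM.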

Compound 4, half-maximal inhibitory concentration: 163000 nM
Compound 4: middle estimate off by 5.8-fold (0.77 log units), on the low side; measured number outside the range, above it.
By their numbers in this assay, from the lowest: compound 1; then compound 3; then compounds 2 and 4 (each within the scatter of the next).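

At the amide-type nitrogen, this assay turns out to be sensitive to a change that leaves the ring type intact: putting the group of 10 heavy atoms in place of the group of 11 heavy atoms gives a 6.8-fold higher number from compound 1 to compound 4 (0.83 log units; beyond the scatter) and is beyond the scatter. Among the compounds shown here, the earlier steps changed only the substituent on the oxygen on the aromatic ring or the carbonyl carbon of that substituent, so this is the first sign that the group on the amide-type nitrogen also counts, and all three single changes from compound 1 now lead to a higher number. No measured information is available to explain this step.

The compounds shown leave open how a longer chain carrying the same ring on the amide-type nitrogen, or an open-chain alkyl group there, would read in this assay. They also leave open whether the same swap on the amide-type nitrogen would have a step of similar size with the free hydroxyl of compound 2 or the larger ester-side group of compound 3.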